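Moving the methyl on the aminopyrimidine of compound 3

A few compounds are considered here, and "the series" means these few. Any claim that something is new, unique, unknown or untested is made for them only; others in the source may bear on it.

Compound 1 `Cc1nc(-c2nn(Cc3ccccc3F)c3ncccc23)oc1CO` in a functional assay (aorta) with Oryctolagus cuniculus as the target (on this read-out higher numbers stand for weaker inhibition and lower numbers for stronger inhibition), gives 900 nM.
Compound 2 `Fc1ccccc1Cn1nc(C2=NCCN2)c2cccnc21` in this assay gives 3200 nM.
Compound 3 `Cc1cnc(-c2nn(Cc3ccccc3F)c3ncccc23)nc1N` in this assay gives 675000 nM.

Compound 3 gives the highest number of the three. Its nearest neighbour is compound 2, with a 210-fold higher number from compound 2 to compound 3 (2.32 log units; beyond the scatter), and the gap to compound 1 is wider still, with a 750-fold higher number from compound 1 to compound 3 (2.88 log units; beyond the scatter). Both steps are large and point the same way: the aminopyrimidine group of compound 3 sits far behind the other two groups at that position.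

Compound 4 `Cc1cc(N)nc(-c2nn(Cc3ccccc3F)c3ncccc23)n1` differs from compound 3 only in where the methyl stands on that ring: 4-amino-6-methylpyrimidin-2-yl in place of 4-amino-5-methylpyrimidin-2-yl on an aromatic carbon. Among the compounds with values here, none of the measured steps moves a group within the same ring; all three exchange one ring for another, so they give no direct guide to this change. What they do show is that the aminopyrimidine as such carries the weakness, and a shift of the methyl within it is not expected to reverse that. The step in this assay is therefore expected to be small, with an estimated 1.5-fold lower number from compound 3 to compound 4 (0.18 log units; within the scatter) in either direction or none beyond the scatter. For compound 4 in this assay the estimate is 450000 nM, within 70000 nM to 2500000 nM.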

Compound 4, half-maximal inhibitory concentration: 536000 nM
Beside the measured number, compound 4's estimate is 1.2-fold (0.08 log units) below it, and the stated range covers the measured number.
By their numbers in this assay, from the lowest: compound 1; then compound 2; then compounds 4 and 3 (each within the scatter of the next).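

In this assay, within the data shown here, the shift from 4-amino-5-methylpyrimidin-2-yl to 4-amino-6-methylpyrimidin-2-yl comes to a 1.3-fold lower number from compound 3 to compound 4 (0.10 log units; within the scatter) and so does not separate the two placements of the methyl, something the earlier steps, each exchanging one ring for another, could not show. The large gap to the other two groups holds for both placements, with a 170-fold higher number from compound 2 to compound 4 (2.22 log units; beyond the scatter) and a 600-fold higher number from compound 1 to compound 4 (2.77 log units; beyond the scatter) in the same direction as the steps to compound 3. Nothing given here accounts for that gap.

From the compounds shown here alone, it remains open whether the gap goes with the amino group or with the pyrimidine ring itself. A hydroxyl or a methoxy group in place of the amino group on the same ring would help to tell these apart.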